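Replacing the Nitrile on the Benzyl Arm

A few compounds are considered here, and "the series" means these few. Any claim that something is new, unique, unknown or untested is made for them only; others in the source may bear on it.

Compound 1 `Cc1ccc(Cc2nc3cc(O[C@H]4CC[C@@H](C(=O)O)CC4)ccc3n2C)cc1`: 150 nM
Compound 2 `Cn1c(Cc2cccc(C(F)(F)F)c2)nc2cc(O[C@H]3CC[C@@H](C(=O)O)CC3)ccc21`: 190 nM
Compound 3 `Cn1c(Cc2cccc(C#N)c2)nc2cc(O[C@H]3CC[C@@H](C(=O)O)CC3)ccc21`: 51000 nM

In an assay on isolated protein for inhibition of Long-chain-fatty-acid--CoA ligase 1 (Homo sapiens), read by mass spectrometry, with a stated time of 90 min, in the presence of a further agent that is not named here (a lower number here means a stronger inhibitor, a higher number a weaker inhibitor), compound 3 stands highest of the three numbers, far from the other two. The steps of a 340-fold higher number from compound 1 to compound 3 (2.53 log units; beyond the scatter) and a 270-fold higher number from compound 2 to compound 3 (2.43 log units; beyond the scatter) are both large, whereas a 1.3-fold higher number from compound 1 to compound 2 (0.10 log units; within the scatter) stays within the scatter. Compound 4 `Cn1c(Cc2ccc3c(c2)OCC3)nc2cc(O[C@H]3CC[C@@H](C(=O)O)CC3)ccc21` differs from compound 3 by a group of 9 heavy atoms (8 carbon, 1 oxygen; one five-membered non-aromatic ring with 1 hetero atom, one six-membered aromatic ring of carbon only) in place of a group of 8 heavy atoms (7 carbon, 1 nitrogen; one six-membered aromatic ring of carbon only), on a saturated chain carbon bound to an aromatic carbon. Going by the values given here, the only measured steps that bear on this change are those into compound 3, in which a ring carrying a nitrile entered and the number rose sharply. Removing that nitrile-bearing ring is therefore expected to bring a large fall, a 170-fold lower number from compound 3 to compound 4 (2.23 log units; beyond the scatter), back toward the region of compound 1 and compound 2. Compound 4 is estimated at 300 nM, with a range from 80 nM to 1500 nM.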

Compound 4, half-maximal inhibitory concentration: 13 nM
Beside the measured number, compound 4's estimate is 23-fold (1.36 log units) above it; measured number outside the range, below it.
By their numbers in this assay, from the lowest: compound 4; then compounds 1 and 2 (each within the scatter of the next); then compound 3.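

The group with the five-membered non-aromatic ring does more than recover what the 3-cyanophenyl group lost, giving a 3900-fold lower number from compound 3 to compound 4 (3.59 log units; beyond the scatter). It also surpasses both other groups at this place, with a 15-fold lower number from compound 2 to compound 4 (1.16 log units; beyond the scatter) and a 12-fold lower number from compound 1 to compound 4 (1.06 log units; beyond the scatter), so the earlier compounds had not shown the best result available here. No measurement shown gives a reason for these steps. Still open, as far as these compounds go, is whether the oxygen of the new ring matters, which a matching all-carbon ring would test, and how an amine or a methoxy group on the phenyl ring would compare.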